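The source may report more compounds than this note shows. Statements on the series, on what has been measured and on what is new or still open speak of the compounds shown alone.

Measured so far:
Compound 1, `Cc1c(C(C)C)c(=O)on1C(=O)N1CCCCC1`, gives 2 nM in an assay (strain Wistar) for inhibition of Hormone-sensitive lipase (Rattus norvegicus), read by spectrophotometry; a higher number here means a weaker inhibitor, a lower number a stronger inhibitor.
Compound 2, `Cc1c(C(C)C)c(=O)on1C(=O)N(C)CC(N)=O`, reaches only the limit of the assay, reported as > 1000 nM.

Compound 2 thus stands at the limit of this assay, the point at which one of the two values shown sits (the limit of > 1000 nM in this assay, at which 1 of the 2 values shown sits); only a limit, not a number, is known for it. Compound 3, `Cc1c(C(C)C)c(=O)on1C(=O)N1CCNCC1`, differs from compound 2 by piperazin-1-yl in place of (carbamoylmethyl)(methyl)amino on a carbonyl carbon. Among the compounds with values here, the one measured step that bears on this change is an at least 500-fold higher number from compound 1 to compound 2 (2.69 log units; beyond the scatter), which ran in the opposite direction, from a six-membered ring to the open-chain (carbamoylmethyl)(methyl)amino group, and was large. Compound 3 returns to a six-membered non-aromatic ring on the carbonyl carbon, so a large step downward in this assay is expected, an at least 50-fold lower number from compound 2 to compound 3 (1.69 log units; beyond the scatter). Compound 3 is therefore estimated at 20 nM, with a range from 3 nM to 300 nM.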

Compound 3, half-maximal inhibitory concentration: > 1000 nM
Compound 3 ended at the assay's limit; the forecaster's own chance of this, stated with the estimate: 15%; at least 50-fold (1.69 log units) between middle value and limit.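

Compound 3 shows that a six-membered non-aromatic ring on this carbonyl carbon is not enough to keep the strength of compound 1 in this assay. Piperazin-1-yl in place of piperidin-1-yl gives an at least 500-fold higher number from compound 1 to compound 3 (2.69 log units; beyond the scatter), so a change within the ring alone can cost as much as opening it to the chain of compound 2. The step between compound 2 and compound 3 cannot be read, and both now rest at the same ceiling: the limit of > 1000 nM in this assay, at which 2 of the 3 values shown sit.

From the compounds shown here alone, how far compound 2 and compound 3 each lie past that limit stays unknown. Also open, going by these compounds, is whether a morpholine ring, or a piperazine ring carrying a methyl group on its second nitrogen, would move the value back toward that of compound 1.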